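The compounds below may be only part of what the source reports. "The series", "measured", "known", "first", "only" and "open" are said of these compounds alone.

Within the data shown here, compound 3 `COc1cc(-c2ccnc3cc(-c4c[nH]c5ccccc45)nn23)cc(OC)c1OC` stands second highest of the three numbers so far in a functional assay on HeLa cells (Homo sapiens) for inhibition, read by CCK-8 assay, with a stated time of 48 h; on this read-out lower numbers stand for stronger inhibition and higher numbers for weaker inhibition: compound 3 gives 195 nM, while compound 2 `COc1cc(-c2ccnc3cc(-c4ccc5cc[nH]c5c4)nn23)cc(OC)c1OC` gives 125 nM and compound 1 `COc1cc(-c2ccnc3cc(-c4ccc(Cl)cc4)nn23)cc(OC)c1OC` gives 1490 nM. The gap between compounds 3 and 2 is small, a 1.6-fold higher number from compound 2 to compound 3 (0.19 log units; within the scatter), whereas the gap to compound 1 is large, a 7.6-fold lower number from compound 1 to compound 3 (0.88 log units; beyond the scatter). Compound 4 `COc1cc(-c2ccnc3cc(-c4ccccc4)nn23)cc(OC)c1OC` differs from compound 3 in one place: phenyl in place of 1H-indol-3-yl on an aromatic carbon. The step that bears most directly on this change runs the other way, a 7.6-fold lower number from compound 1 to compound 3 (0.88 log units; beyond the scatter), and the companion step a 12-fold lower number from compound 1 to compound 2 (1.08 log units; beyond the scatter) points the same way: a bicyclic group with a hydrogen-bond donor, whether 1H-indol-6-yl or 1H-indol-3-yl, gave a much lower number than 4-chlorophenyl. Removing that group in favour of plain phenyl is therefore expected to move the number back toward that of compound 1, so for compound 4 a step of a 9.2-fold higher number from compound 3 to compound 4 (0.97 log units; beyond the scatter) is expected in this assay. Compound 4 is estimated at 1800 nM, with a range from 600 nM to 6000 nM.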

Compound 4, half-maximal inhibitory concentration: 458 nM
The estimate for compound 4 lay 3.9-fold (0.59 log units) above the measured number, outside the stated range (below it).
By their numbers in this assay, from the lowest: compounds 2 and 3 (each within the scatter of the next); then compound 4; then compound 1.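

Replacing the indole with plain phenyl at this carbon of the five-membered ring in this assay gives a 2.3-fold higher number from compound 3 to compound 4 (0.37 log units; beyond the scatter) and a 3.7-fold higher number from compound 2 to compound 4 (0.56 log units; beyond the scatter) and so leaves both indoles ahead of phenyl beyond the scatter. The other new step, a 3.3-fold lower number from compound 1 to compound 4 (0.51 log units; beyond the scatter) for hydrogen in place of chloro, shows that part of the earlier drop from compound 1 to the indoles needs no indole at all, as losing the chloro alone already lowers the number. Nothing given here accounts for either change.

Phenyl and the indoles differ in both ring count and the indole hydrogen, so the compounds shown do not separate these two features. A 1-methyl-1H-indol-3-yl group would address that, while a methoxy group or an amine on the phenyl would test whether chloro is a special case among phenyl substituents.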